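The source may report more compounds than this note shows. Statements on the series, on what has been measured and on what is new or still open speak of the compounds shown alone.

Measured in a functional assay on HepG2 cells (Homo sapiens) for antiproliferative activity, read by MTT assay, with a stated time of 48 h; a higher number here means a weaker inhibitor, a lower number a stronger inhibitor:
- compound 1 `O=C(CN1CCCC1)Nc1ccc2ncnc(Nc3cccc(C(F)(F)F)c3)c2c1`: 25200 nM
- compound 2 `O=C(CN1CCCCC1)Nc1ccc2ncnc(Nc3cccc(C(F)(F)F)c3)c2c1`: > 100000 nM (a limit)

In this assay, going by the values given here, compound 1 gives 25200 nM, the only exact number so far. Compound 2 is reported only as a limit, > 100000 nM.

Compound 3 `O=C(CN1CCCC1)Nc1ccc2ncnc(Nc3ccc(Cl)c(C(F)(F)F)c3)c2c1` changes compound 1 in one place: chloro in place of hydrogen on an aromatic carbon, ortho to a trifluoromethyl group. Among the compounds with values here, the single measured step, an at least 3.9-fold higher number from compound 1 to compound 2 (0.59 log units; beyond the scatter), concerns a different place, the pyrrolidin-1-yl group, so it gives no direct guide to the size or direction of this change. No step beyond the scatter is therefore expected, though with wide uncertainty. The estimated step is a 1.4-fold lower number from compound 1 to compound 3 (0.15 log units; within the scatter). For compound 3 the expected value is 18000 nM, with an estimated range from 4000 nM to 70000 nM.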

Compound 3, half-maximal inhibitory concentration: > 100000 nM
Compound 3: no number, only a limit (the forecaster's own chance of this, stated with the estimate: 15%); middle value at least 5.5-fold (0.74 log units) from the limit.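

In this assay, placing one chloro on the aromatic carbon ortho to the trifluoromethyl group gives an at least 3.9-fold higher number from compound 1 to compound 3 (0.59 log units; beyond the scatter). Going by these compounds alone, this shows that the ring carrying the trifluoromethyl group, unchanged in the earlier compounds, is also sensitive: a single added heavy atom at this carbon clearly weakens the compound. Compound 3 is reported only as a limit, and the full size of the step stays unknown because of that limit: the limit of > 100000 nM in this assay, at which 2 of the 3 values shown sit.

On these data alone, whether fluoro, methyl or an amine at this carbon would be tolerated remains open. So does whether a chloro-free compound with another group here could improve on compound 1.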